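From 3,4-dimethylphenyl to 3,4-dihydroxyphenyl in the series

The source may hold more compounds than are shown below. What is called first, only, known or untested is meant among the compounds shown, and "the series" means these compounds.

For the measured compounds named here, in a functional assay on SK-OV-3 cells (Homo sapiens) for cytotoxicity (on this read-out lower numbers stand for stronger inhibition of growth and higher numbers for weaker inhibition of growth), compound 3 `CSc1ccc(C2=C(c3ccc(C)c(C)c3)C(=O)N3CCCC3C2)cc1` gives 300 nM, the lowest number so far, and compound 2 `COc1ccc(C2=C(c3ccc(SC)cc3)CC3CCCN3C2=O)cc1Br` stands nearest at 3000 nM. For compound 1 `COc1ccc(C2=C(c3ccc(SC)cc3)CC3CCCN3C2=O)cc1O` the reading is > 100000 nM, which is a limit of the assay. In compound 4 `CSc1ccc(C2=C(c3ccc(O)c(O)c3)C(=O)N3CCCC3C2)cc1`, 3,4-dihydroxyphenyl takes the place of 3,4-dimethylphenyl on a double-bonded ring carbon (3,4-dihydroxyphenyl in place of 3,4-dimethylphenyl on a double-bonded ring carbon). The closest evidence is an at least 330-fold lower number from compound 1 to compound 3 (2.52 log units; beyond the scatter) and an at least 33-fold lower number from compound 1 to compound 2 (1.52 log units; beyond the scatter), both large and both removing a hydroxy group, while a 10-fold lower number from compound 2 to compound 3 (1.00 log units; beyond the scatter) is modest. Reversing that trend, the step expected in this assay is a 50-fold higher number from compound 3 to compound 4 (1.70 log units; beyond the scatter), large and towards weaker growth inhibition. The estimate for compound 4 is 15000 nM, with an expected range of 2000 nM to 100000 nM.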

Compound 4, concentration for 50% growth inhibition: 80000 nM
The estimate for compound 4 lay 5.3-fold (0.73 log units) below the measured number; the measured number falls inside the stated range.
By their numbers in this assay, from the lowest: compound 3; then compound 2; then compound 4. At a limit, above all of these: compound 1.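

In this assay, 3,4-dihydroxyphenyl on the double-bonded ring carbon gives a 270-fold higher number from compound 3 to compound 4 (2.43 log units; beyond the scatter) and a 27-fold higher number from compound 2 to compound 4 (1.43 log units; beyond the scatter), both large and towards weaker growth inhibition. A hydroxy-bearing ring at this position now has a measured number rather than a limit, and it stays far from the two compounds without a hydroxy group. Hydrogen in place of methyl on an oxygen on an aromatic ring gives an at least 1.2-fold lower number from compound 1 to compound 4 (0.09 log units; that floor lies within the scatter). That step is only a floor because compound 1 stands at a limit: the limit of > 100000 nM in this assay, at which 1 of the 4 values shown sits.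

Going by these compounds, whether the weak reading follows the hydroxy groups themselves remains open. An amine or a carboxylic acid on this ring would test that in this assay.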